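Swapping the Aryl Group on Compound 3

The source may report more compounds than this note shows. Statements on the series, on what has been measured and on what is new or still open speak of the compounds shown alone.

Values in a toxicity assay on HUVEC cells (Homo sapiens) for inhibition (a lower number here means a stronger inhibitor of growth, a higher number a weaker inhibitor of growth), so far
Compound 1 `Cc1nc(-c2ccccc2)c(C(=O)N2CCN(c3cccc(Cl)c3)CC2)o1` gives 0.463 ug/mL
Compound 2 `COc1cc(OC)cc(N2CCN(C(=O)c3oc(C)nc3-c3ccccc3F)CC2)c1` gives 0.118 ug/mL
Compound 3 `Cc1nc(-c2ccccc2)c(C(=O)N2CCN(c3cccc(F)c3)CC2)o1` gives 1.05 ug/mL

Compound 3 has the highest number of the three in this assay, making it the weakest growth inhibitor here. Compound 4 `COc1cc(OC)cc(N2CCN(C(=O)c3oc(C)nc3-c3ccccc3)CC2)c1` is reached from it by one change, 3,5-dimethoxyphenyl in place of 3-fluorophenyl on an amine nitrogen in a ring. Going by the values given here, the only measured step, a 2.3-fold higher number from compound 1 to compound 3 (0.36 log units; beyond the scatter), is modest and involves fluoro in place of chloro, so it offers limited guidance. Better evidence is compound 2 (0.118 ug/mL), which carries the same 3,5-dimethoxyphenyl but also differs elsewhere. A drop beyond the scatter is therefore expected, an estimated 4.2-fold lower number from compound 3 to compound 4 (0.62 log units; beyond the scatter). The expected value for compound 4 is 0.25 ug/mL (estimated range 0.07 ug/mL to 0.9 ug/mL).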

Compound 4, concentration for 50% growth inhibition: 0.319 ug/mL
Beside the measured number, compound 4's estimate is 1.3-fold (0.11 log units) below it, within the range that was stated.
By their numbers in this assay, from the lowest: compound 2; then compounds 4 and 1 (each within the scatter of the next); then compound 3.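

In this assay, the group on the ring nitrogen clearly matters: 3,5-dimethoxyphenyl in place of 3-fluorophenyl gives a 3.3-fold lower number from compound 3 to compound 4 (0.52 log units; beyond the scatter), while in place of 3-chlorophenyl it gives only a 1.5-fold lower number from compound 1 to compound 4 (0.16 log units; within the scatter). Hydrogen in place of fluoro on the other aromatic ring gives a 2.7-fold higher number from compound 2 to compound 4 (0.43 log units; beyond the scatter), so 3,5-dimethoxyphenyl alone does not account for the low number of compound 2. Nothing shown here explains these differences. Going by these compounds, how a benzyl group or a single methoxy on the phenyl ring would compare at this nitrogen remains open.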